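This account rests on a few compounds, and the source may have more. Where it says the series, first, only, none or still open, it means among the compounds named here.

In an ADME assay on HEK293 cells (Homo sapiens) for cytotoxicity, with a stated time of 72 h (on this read-out lower numbers stand for an effect already at smaller amounts and higher numbers for an effect only at larger amounts of compound), compound 3 (`CSc1ccccc1NC(=O)Nc1cc(C)nc2ccccc12`) has no measured number. Compound 3 reads > 25000 nM, which is a limit of the assay. Compound 1 (`Cc1cc(NC(=O)Nc2ccccc2OC(F)(F)F)c2ccccc2n1`) reads > 25000 nM, which is also a limit. Compound 2 (`Cc1ccc(NC(=O)Nc2cc(C)nc3ccccc23)cc1`) reads > 25000 nM, again a limit. The whole set so far is described by the limit of > 25000 nM in this assay, at which 3 of the 3 values shown sit, so compound 3 cannot be ranked against the other two.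

Compound 4 (`Cc1cc(NC(=O)Nc2ccccc2C(F)(F)F)c2ccccc2n1`) keeps the core of compound 3 and carries trifluoromethyl in place of methylsulfanyl on an aromatic carbon. Among the measured compounds shown here, the one measured step that bears on this change is a step that the two limits leave unreadable from compound 1 to compound 3, with methylsulfanyl in place of trifluoromethoxy on an aromatic carbon. That step offers no size to carry over, and both of its ends rest at a limit. No step beyond the scatter is therefore expected in this assay, in either direction, and compound 4 is expected to be reported as a limit as well. The expected change is a number no higher from compound 3 to compound 4 (the limit leaves the size open). Should a number be reported, compound 4 is estimated at 25000 nM. The expected range for compound 4 runs from 12500 nM to 50000 nM.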

Compound 4, half-maximal effective concentration: > 25000 nM
Compound 4: a limit, no number; the forecaster's own chance of this, stated with the estimate: 85%; the middle value sits exactly at the limit.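

In this assay, among the compounds shown here, compound 4 reads > 25000 nM, which is a limit of the assay and not a number, so no step to compound 4 from compound 1 or compound 3 can be read. The compounds shown leave open how far any of these changes of group moves the read-out, because every value stands at the same limit: the limit of > 25000 nM in this assay, at which 4 of the 4 values shown sit.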